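The compounds below may be only part of what the source reports. "The series", "measured", "known", "first", "only" and "open" are said of these compounds alone.

Compound 2 `COc1cccc(CNCCCNc2ccnc3cc(Cc4ccc(F)cc4Cl)ccc23)c1O` gives 2350 nM in an ADME assay on HepG2 cells (Homo sapiens) for cytotoxicity, read by luminescence, CellTiter-Glo and ATP content, with a stated time of 72 h (a higher number here means that more compound is needed for the effect, a lower number that less compound is needed), and stands alongside compound 1 `COc1cccc(CNCCCNc2ccnc3cc(-c4ccc(C(F)(F)F)cc4)ccc23)c1O`, which gives 2210 nM in this assay, the two numbers within the scatter of each other. Going by the values given here, the only measured step at this position, a 1.1-fold higher number from compound 1 to compound 2 (0.03 log units; within the scatter), is the one that bears on the next change. Compound 3 `COc1cccc(CNCCCNc2ccnc3cc(-c4cccc5ccccc45)ccc23)c1O` differs from compound 2 by naphthalen-1-yl in place of 2-chloro-4-fluorobenzyl on an aromatic carbon. Because a 1.1-fold higher number from compound 1 to compound 2 (0.03 log units; within the scatter) stayed within the scatter, no step beyond the scatter is expected in this assay for the present exchange either. Compound 3 is therefore estimated at 2300 nM, with a range of 1200 nM to 4500 nM, an expected step of a 1.0-fold lower number from compound 2 to compound 3 (0.01 log units; within the scatter).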

Compound 3, half-maximal effective concentration: 2520 nM
Estimate against measurement, compound 3: 1.1-fold (0.04 log units) below, within the range that was stated.
By their numbers in this assay, from the lowest: compounds 1, 2 and 3 (each within the scatter of the next).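

In this assay the two-ring naphthalen-1-yl gives a 1.1-fold higher number from compound 2 to compound 3 (0.03 log units; within the scatter) and also a 1.1-fold higher number from compound 1 to compound 3 (0.06 log units; within the scatter) in the comparison with the earlier trifluoromethyl-bearing group, both within the scatter. This position therefore now spans single-ring and two-ring carbon aromatics, with or without fluorine and chlorine, and the three compounds read alike. Nothing measured here offers an explanation for this flat reading.

From the compounds shown here alone, whether it holds for a group of another kind on this aromatic carbon, such as an amine or a carboxylic acid, stays open. Going by these compounds, the effect of a longer chain elsewhere on the shared core is also open.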